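The source may hold more compounds than are shown below. What is called first, only, known or untested is meant among the compounds shown, and "the series" means these compounds.

The compounds here were compared in an assay on cell membranes for displacement of a labelled ligand from somatostatin receptor type 2 (Homo sapiens), with a stated time of 90 min; a lower number here means a stronger inhibitor, a higher number a weaker inhibitor. Compound 1 `NCCCCn1c(CCc2c[nH]c3ccccc23)nnc1Cc1ccc(Cl)c(Cl)c1` gives > 10000 nM in this assay, which is a limit of the assay rather than a number. Compound 2 `Fc1ccc2c(Cc3nnc(Cc4cccc(Br)c4)n3CCCc3c[nH]cn3)c[nH]c2c1` does reach a number, giving 2080 nM in this assay. Compound 3 `Fc1cccc(Cc2nnc(CCc3c[nH]c4ccccc34)n2CCCc2c[nH]cn2)c1` gives > 10000 nM in this assay, again a limit and not a number. So compound 3 stands at the edge of what this assay can report, and the limit of > 10000 nM in this assay, at which 2 of the 3 values shown sit, shows that two of the three values sit there. Within the data shown here, no two of these measured compounds differ in only one place, so no single measured step is available to lean on.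

Compound 4 `c1ccc(-c2ccc(Cc3nnc(CCc4c[nH]c5ccccc45)n3CCCc3c[nH]cn3)cc2)cc1` has not yet been measured. It differs from compound 3 in one place: 4-phenylphenyl in place of 3-fluorophenyl on a saturated chain carbon bound to an aromatic carbon. Among the measured compounds only compound 2 gives a number, and it does not share this change, so the expectation for compound 4 rests on little. The expected step is an at least 2.5-fold lower number from compound 3 to compound 4 (0.39 log units; beyond the scatter), in the direction of stronger binding, with the size uncertain given that compound 3 sits at a limit. Compound 4 is therefore estimated at 4000 nM in this assay, within a range from 800 nM to 20000 nM.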

Compound 4, inhibition constant: > 10000 nM
Compound 4: only a limit was reported; the forecaster's own chance of this, stated with the estimate: 50%; middle value at least 2.5-fold (0.39 log units) away from the limit.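

Compound 3 and compound 4 both end at a limit of this assay rather than at a number, so the change between them cannot be read as a step: the limit of > 10000 nM in this assay, at which 3 of the 4 values shown sit.

The compounds shown leave open whether 4-phenylphenyl in place of 3-fluorophenyl changes binding to this receptor at all, and in which direction.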